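Ester Swap on a Thiophene Analogue: An Expected Value

The source may hold more compounds than are shown below. What is called first, only, known or untested is meant among the compounds shown, and "the series" means these compounds.

In an assay on membranes from HeLa cells for displacement of a labelled ligand from adenosine receptor A3 (Homo sapiens), read by scintillation counting, with a stated time of 180 min, tested at 1 uM (a higher number here means more inhibition at the concentration tested (going by the name of the read-out), a lower number less inhibition), compound 1 `CC1=C(C(=O)OC(C)(C)C)C(c2ccco2)NC(=S)N1` gives 9%.
In this assay compound 2 `CC1=C(C(=O)OCc2ccccc2)C(c2ccco2)NC(=S)N1` gives 4%.
In this assay compound 3 `CC1=C(C(=O)OC(C)(C)C)C(c2ccsc2)NC(=S)N1` gives 16%.

All three compounds share one core, a six-membered non-aromatic ring with two nitrogens, carrying a methyl group, an ester and a five-membered aromatic ring. Compound 1 and compound 3 differ only in that five-membered ring: thiophen-3-yl in place of furan-2-yl on a saturated ring carbon. The measured step of a number 7 percentage points higher from compound 1 to compound 3 (within the scatter) is small, so the two values cannot be told apart with confidence. Compound 3 shows the highest of the three numbers, but since its gap to compound 1 is within the scatter, no ordering between them is claimed.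

Compound 1 and compound 2 differ in the ester: benzyl in place of tert-butyl on an oxygen next to a carbonyl group. This change gave a number 5 percentage points lower from compound 1 to compound 2 (within the scatter), again a step that is within the scatter.

Compound 4 `CC1=C(C(=O)OCc2ccccc2)C(c2ccsc2)NC(=S)N1` has not yet been measured. It differs from compound 3 by benzyl in place of tert-butyl on an oxygen next to a carbonyl group, the same change that turned compound 1 into compound 2, made at the same place on the shared core. Among the compounds with values here, with only one earlier example of this change, the expectation rests on that single step: the estimate for compound 4 means a number 5 percentage points lower from compound 3 to compound 4 (within the scatter), because a number 5 percentage points lower from compound 1 to compound 2 (within the scatter) was the size of the step seen before. Compound 4 is therefore expected to give about 11% in this assay, with a likely range from 1% to 22%.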

Compound 4, a percentage reported as inhibition, at one concentration (the size of the read-out at that concentration, not a potency): 2%
For compound 4 the middle estimate is 9 percentage points above the measured one, and the stated range covers the measured number.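

Replacing tert-butyl with benzyl on the thiophen-3-yl compounds gave a number 14 percentage points lower from compound 3 to compound 4 (beyond the scatter) in this assay, and this step cannot be told apart from the one seen earlier on the furan-2-yl compounds: the same change on two cores in this assay, a number 5 percentage points lower (within the scatter) from compound 1 to compound 2 and a number 14 percentage points lower (beyond the scatter) from compound 3 to compound 4, 9 percentage points apart, within the scatter of two such steps. The other change in the set, thiophen-3-yl in place of furan-2-yl, gave a number 2 percentage points lower from compound 2 to compound 4 (within the scatter) with the benzyl ester in place, and this step also cannot be told apart from its earlier counterpart: the same change on two cores in this assay, a number 7 percentage points higher (within the scatter) from compound 1 to compound 3 and a number 2 percentage points lower (within the scatter) from compound 2 to compound 4, 9 percentage points apart, within the scatter of two such steps. So both changes carried over between these two cores without a detectable difference in step size, but this rests on only two pairs of compounds, with the ester step within the scatter on one core and beyond it on the other, and it does not show that the ester change has a fixed size or would carry over to any other core.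

The compounds shown leave open how other groups on the ester oxygen, such as ethyl or a longer chain, would read in this assay, and whether an amide in place of the ester would follow the same trend. They also leave open how a phenyl or pyridine ring in place of the five-membered ring would read, and what potency any of these compounds has, as each value comes from one concentration.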